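This account rests on a few compounds, and the source may have more. Where it says the series, first, only, none or still open, it means among the compounds named here.

Measured compounds:
Compound 1, `O=S(=O)(Nc1ccc(-c2nc3ccccc3o2)cc1)c1ccc(F)c(C(F)(F)F)c1`: in an assay on cells for inhibition of HSP60/HSP10 (Homo sapiens), with a stated time of 60 min (on this read-out lower numbers stand for stronger inhibition and higher numbers for weaker inhibition), compound 1 gives 28000 nM.
Compound 2, `Cc1cccc(S(=O)(=O)Nc2ccc3oc(-c4ccccc4)nc3c2)c1`: in this assay compound 2 gives > 100000 nM, which is a limit of the assay rather than a number.

Compound 2 therefore stands at the limit of > 100000 nM in this assay, at which 1 of the 2 values shown sits. For the measured compounds named here, of the two measured compounds, compound 1 is the only one with a numerical value, and no step between the two has been computed, so what their values show is only that compound 1 has a number while compound 2 has a limit.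

Compound 3, `O=S(=O)(Nc1ccc2oc(-c3ccccc3)nc2c1)c1ccc(Cl)s1`, differs from compound 2 in one place: 5-chlorothiophen-2-yl in place of 3-methylphenyl on a sulfonyl sulfur. Nothing in the measured set speaks to this exchange of a six-membered carbon ring for a five-membered ring with one hetero atom, and compound 2 itself offers only a limit to build on. The step expected from compound 2 to compound 3 in this assay is an at least 1.1-fold lower number from compound 2 to compound 3 (0.04 log units; that floor lies within the scatter), which in direction means little more than none beyond the scatter, given that compound 2 has only a limit. Compound 3 is estimated at 90000 nM, within a range of 25000 nM to 300000 nM.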

Compound 3, half-maximal inhibitory concentration: 70000 nM
Compound 3: the middle estimate sits 1.3-fold (0.11 log units) above what was measured; low and high end bracket the measured number.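

For the compounds shown here, with compound 3, the place on the sulfonyl sulfur yields a readable step for the first time: in this assay, 5-chlorothiophen-2-yl in place of 3-methylphenyl gives an at least 1.4-fold lower number from compound 2 to compound 3 (0.15 log units; that floor lies within the scatter). It also shows that, on the core shared by these two compounds, a five-membered aromatic ring with one hetero atom can bring the read-out inside the measurable range, since compound 3 gives 70000 nM. The step remains a floor rather than a size because compound 2 stands at a limit of the assay and not at a number: the limit of > 100000 nM in this assay, at which 1 of the 3 values shown sits.

The compounds shown leave open whether the chlorine or the ring itself accounts for the exchange, which a plain thiophen-2-yl group or a 3-chlorophenyl group on the same sulfonyl sulfur would separate. They also leave open how this place responds to other kinds of group, such as an amine or a carboxylic acid, and how compound 1 relates to the other two, as it differs from them in more than one place.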